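The compounds below may be only part of what the source reports. "The series", "measured", "known", "first", "only" and "open" are said of these compounds alone.

- Compound 1 `O=C(NO)c1ccc(/C=C/c2cccc(-c3cccc(O)c3)c2)cc1`: > 10000 nM, a limit
- Compound 2 `Cc1ccc(-c2cncc(/C=C/c3ccc(C(=O)NO)cc3)c2)cc1`: > 10000 nM, a limit
- Compound 3 `Cc1ccc(-c2cncc(/C=C/c3ccc(C(=O)NO)cc3)c2)c(F)c1`: 2990 nM

Going by the values given here, in a functional assay on HCT-116 cells (Homo sapiens) for antiproliferative activity, read by CellTiter-Glo, with a stated time of 72 h (a lower number here means a stronger inhibitor, a higher number a weaker inhibitor), compound 3 at 2990 nM holds the only actual number, and the rest sit at the limit of > 10000 nM in this assay, at which 2 of the 3 values shown sit. Compound 4 `O=C(NO)c1ccc(/C=C/c2cncc(-c3ccccc3O)c2)cc1` is not yet measured. It differs from compound 3 as follows: 2-hydroxyphenyl in place of 2-fluoro-4-methylphenyl on an aromatic carbon. This puts 2-hydroxyphenyl in place of 2-fluoro-4-methylphenyl, so the fluoro is lost. Among the compounds with values here, the one measured step that bears on this is the gain on adding fluoro, an at least 3.3-fold lower number from compound 2 to compound 3 (0.52 log units; beyond the scatter). A partial loss of that gain is therefore expected in this assay, towards a higher number. The expected change is a 1.7-fold higher number from compound 3 to compound 4 (0.22 log units; within the scatter). For compound 4 the estimated value is 5000 nM, with an expected range of 2000 nM to 10000 nM.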

Compound 4, half-maximal inhibitory concentration: 4680 nM
For compound 4 the middle estimate is 1.1-fold (0.03 log units) above the measured one; low and high end bracket the measured number.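

In this assay, 2-hydroxyphenyl in place of 2-fluoro-4-methylphenyl at this position gives a 1.6-fold higher number from compound 3 to compound 4 (0.19 log units; within the scatter), so activity at this level does not depend on the fluoro. Against the 4-methylphenyl group, the same 2-hydroxyphenyl group gives an at least 2.1-fold lower number from compound 2 to compound 4 (0.32 log units; beyond the scatter), which shows that a second group here also clears the limit. That step has an open end, as the value of compound 2 is a limit: the limit of > 10000 nM in this assay, at which 2 of the 4 values shown sit.

As far as these compounds go, whether an amine or a carboxylic acid in place of the hydroxyl would keep this activity remains open. So does whether a methoxy group would.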